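The source may report more compounds than this note shows. Statements on the series, on what has been measured and on what is new or still open speak of the compounds shown alone.

- compound 1 `OC1CCN(c2nccnc2OC2CN(c3ccc4ccccc4n3)C2)CC1`: 99000 nM
- compound 2 `N#CC1CCN(c2nccnc2OC2CN(c3ccc4ccccc4n3)C2)CC1`: 66000 nM
- compound 3 `OCc1cccc(-c2nccnc2OC2CN(c3ccc4ccccc4n3)C2)c1`: 29000 nM

In a physicochemical assay for solubility, in phosphate buffer, at pH 7.4 (on this read-out higher numbers stand for higher solubility and lower numbers for lower solubility), compound 3 stands lowest of the three at 29000 nM. The next change leads to compound 4 `c1ccc(-c2nccnc2OC2CN(c3ccc4ccccc4n3)C2)nc1`, with pyridin-2-yl in place of 3-(hydroxymethyl)phenyl on an aromatic carbon. Two measured steps bring in 3-(hydroxymethyl)phenyl at this same place: a 3.4-fold lower number from compound 1 to compound 3 (0.53 log units; beyond the scatter) and a 2.3-fold lower number from compound 2 to compound 3 (0.36 log units; beyond the scatter). Both are modest. The remaining step, a 1.5-fold lower number from compound 1 to compound 2 (0.18 log units; within the scatter), concerns a different exchange and stays within the scatter. Within the data shown here, no measured step connects two aromatic groups at this place, so the evidence is indirect. Given the modest size of those two steps, only a small shift is anticipated in this assay, with no clear direction. The expected step is a 1.2-fold lower number from compound 3 to compound 4 (0.06 log units; within the scatter), and none beyond the scatter is expected. For compound 4 the estimated value is 25000 nM, with an expected range of 9000 nM to 70000 nM.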

Compound 4, solubility: 349000 nM
Compound 4: the middle estimate sits 14-fold (1.14 log units) below what was measured, outside the stated range (above it).
By their numbers in this assay, from the lowest: compound 3; then compounds 2 and 1 (each within the scatter of the next); then compound 4.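

At this place, next to the ring nitrogen, the exchange of one aromatic group for another is not a neutral one in this assay: pyridin-2-yl gives a 12-fold higher number from compound 3 to compound 4 (1.08 log units; beyond the scatter) and the largest step in the series. The same group also gives a 5.3-fold higher number from compound 2 to compound 4 (0.72 log units; beyond the scatter) and a 3.5-fold higher number from compound 1 to compound 4 (0.55 log units; beyond the scatter) so the earlier picture, in which both steps at this place led downward from the piperidines, holds only for 3-(hydroxymethyl)phenyl, and an aromatic group here does not by itself set the direction. Nothing measured here accounts for this rise.

Going by these compounds, whether the rise goes with the ring nitrogen or with the loss of the hydroxymethyl stays open. Also open, on these data alone, is how an unsubstituted phenyl, a pyridin-3-yl or a morpholin-4-yl at this place would read in this assay against these values.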